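Amide acyl swap on the trimethoxyanilide series

The compounds below may be only part of what the source reports. "The series", "measured", "known", "first", "only" and "open" are said of these compounds alone.

Measured compounds:
compound 1 `C/C=C/C=C/C(=O)N(Cc1ccc(OC)c(O)c1)c1cc(OC)c(OC)c(OC)c1` — 180 nM
compound 2 `COc1ccc(N(Cc2cc(OC)c(OC)c(OC)c2)C(=O)CN=[N+]=[N-])cc1O` — 26100 nM
compound 3 `COc1ccc(CNc2cc(OC)c(OC)c(OC)c2)cc1` — 4890 nM

In a functional assay on KYSE-450 cells (Homo sapiens) for inhibition, read by MTT assay, with a stated time of 48 h (on this read-out higher numbers stand for weaker inhibition and lower numbers for stronger inhibition), compound 1 gives 180 nM, the lowest number of the three. The nearest is compound 3 with 4890 nM, and compound 2 sits furthest away with 26100 nM; both gaps lie well beyond the scatter, so compound 1 is the strongest inhibitor of the measured set. Going by the values given here, no two measured compounds differ in one place, so no single-point step can be read from the numbers.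

The unmeasured compound 4 `COc1ccc(CN(C(=O)C2CC2)c2cc(OC)c(OC)c(OC)c2)cc1O` keeps the whole frame of compound 1 and changes only the acyl group: cyclopropyl in place of penta-1,3-dien-1-yl on a carbonyl carbon. Nothing measured here speaks directly to this exchange, since compound 2 and compound 3 each differ from compound 1 in more than one place. Among the compounds with values here, compound 1, the only acylated compound with the same phenol pattern, gives 180 nM, and on that basis compound 4 is expected to fall back by a moderate step, a 3.9-fold higher number from compound 1 to compound 4 (0.59 log units; beyond the scatter), towards weaker inhibition but still clearly ahead of compound 3. The estimate for compound 4 in this assay is 700 nM, within a range of 200 nM to 3000 nM.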

Compound 4, half-maximal inhibitory concentration: 80 nM
Compound 4: the middle estimate sits 8.8-fold (0.94 log units) above what was measured; the whole stated range lies above it.
By their numbers in this assay, from the lowest: compound 4; then compound 1; then compound 3; then compound 2.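

In this assay, going by these compounds alone, the exchange of penta-1,3-dien-1-yl for cyclopropyl on a carbonyl carbon gives a 2.3-fold lower number from compound 1 to compound 4 (0.35 log units; beyond the scatter) as the first single-place comparison, a modest step beyond the scatter towards stronger inhibition. Inhibition at this position therefore does not depend on the open chain with its two double bonds: the three-membered carbon ring, with fewer heavy atoms, takes its place with a gain, and compound 4 now carries the lowest number of the four compounds. The data offer nothing that accounts for the direction or the size of this step.

Among the compounds shown, it remains open whether the gain extends to a larger carbocycle such as cyclohexyl, to a short saturated chain such as ethyl, or to an acyl group carrying an amine. Going by these compounds, the role of the hydroxyl group on the shared core also remains open, and the steps to compound 2 and compound 3 cannot be read, since each of them differs from compound 1 and compound 4 in more than one place.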